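A few compounds are considered here, and "the series" means these few. Any claim that something is new, unique, unknown or untested is made for them only; others in the source may bear on it.

Measured so far in an assay for binding affinity to leukotriene B4 receptor 1 (Homo sapiens); a higher number here means a weaker inhibitor, a lower number a stronger inhibitor:
- compound 1 `COc1ccc(CCCCCCCCOc2ccc(C[S+]([O-])c3ccccc3)nc2/C=C/C(=O)O)cc1`: 37 nM
- compound 2 `COc1ccc(CCCCCCCCOc2ccc(CSc3cccc(C(=O)O)c3)nc2/C=C/C(=O)O)cc1`: 80 nM

Within the data shown here, compound 1 stands lowest of the two numbers; the only step, a 2.2-fold higher number from compound 1 to compound 2 (0.33 log units; beyond the scatter), is modest. Compound 3 `COc1ccc(CCCCCCCCOc2ccc(C[S+]([O-])c3cccc(CS(=O)(=O)C(F)(F)F)c3)nc2/C=C/C(=O)O)cc1` keeps the core of compound 1 and carries ((trifluoromethyl)sulfonyl)methyl in place of hydrogen on an aromatic carbon, with the new group on an aromatic carbon of a six-membered aromatic ring of carbon only, meta to a large group. The step from compound 1 to compound 2 also adds a group to that ring but changes the sulfur group at the same time, so it bears only loosely on this change. A step of similar modest size, if any, is expected in this assay: compound 3 is estimated at 50 nM (range 15 nM to 170 nM), a step of a 1.4-fold higher number from compound 1 to compound 3 (0.13 log units; within the scatter).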

Compound 3, inhibition constant: 225 nM
Beside the measured number, compound 3's estimate is 4.5-fold (0.65 log units) below it, and the stated range ends below it.
By their numbers in this assay, from the lowest: compound 1; then compound 2; then compound 3.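

In this assay, ((trifluoromethyl)sulfonyl)methyl in place of hydrogen on an aromatic carbon gives a 6.1-fold higher number from compound 1 to compound 3 (0.78 log units; beyond the scatter), with the sulfur group left unchanged. Among these compounds, the earlier step, a 2.2-fold higher number from compound 1 to compound 2 (0.33 log units; beyond the scatter), changed the sulfur group as well, so this is the only reading of an added group alone on this ring, and this group is not tolerated here without a clear loss. Nothing available here accounts for that loss.

Going by these compounds, whether the whole group or only part of it carries the loss stays open. A plain methyl or a nitrile on the same aromatic carbon, on the core of compound 1, would test this.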